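A few compounds are considered here, and "the series" means these few. Any claim that something is new, unique, unknown or untested is made for them only; others in the source may bear on it.

Measured in a functional assay on V79 cells (Cricetulus griseus) for cytotoxicity, read by colony formation; on this read-out lower numbers stand for stronger inhibition and higher numbers for weaker inhibition:
- compound 1 `Nc1c(F)c(N2CCC(N)C2)c(F)c2c1c(=O)c(C(=O)O)cn2C1CC1`: 15 ug/mL
- compound 2 `Nc1c(F)c(N2CCC(N)C2)c(Cl)c2c1c(=O)c(C(=O)O)cn2C1CC1`: 59 ug/mL
- compound 3 `COc1c(N2CCC(N)C2)c(F)c(N)c2c(=O)c(C(=O)O)cn(C3CC3)c12`: 100 ug/mL

Compound 2 stands among the higher numbers of this small set. The gap a 1.7-fold higher number from compound 2 to compound 3 (0.23 log units; within the scatter) leaves those two unresolved, while a 3.9-fold higher number from compound 1 to compound 2 (0.59 log units; beyond the scatter) is a modest but clear separation.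

Compound 4 `NC1CCN(c2c(F)c(Cl)c3c(=O)c(C(=O)O)cn(C4CC4)c3c2Cl)C1` carries chloro in place of amino on an aromatic carbon. That carbon is ortho to a fluoro group and para to a chloro group.

For the measured compounds named here, no measured step makes this exchange, since all three measured compounds keep the amino group. The nearest guides are exchanges on a different aromatic carbon: a 3.9-fold higher number from compound 1 to compound 2 (0.59 log units; beyond the scatter) and a 6.7-fold higher number from compound 1 to compound 3 (0.82 log units; beyond the scatter). Both are modest, so they suggest a change of limited size but set no direction for the new exchange. Going by the values given here, no step clearly beyond the scatter is therefore expected in this assay, although one cannot be ruled out.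

The expected change is a 1.5-fold lower number from compound 2 to compound 4 (0.17 log units; within the scatter). For compound 4 the estimated value is 40 ug/mL, with an expected range from 12 ug/mL to 130 ug/mL.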

Compound 4, half-maximal inhibitory concentration: > 500 ug/mL
Compound 4: no number, only a limit; the forecaster's own chance of this, stated with the estimate: 10%; at least 12-fold (1.09 log units) between middle value and limit.
By their numbers in this assay, from the lowest: compound 1; then compounds 2 and 3 (each within the scatter of the next). At a limit, above all of these: compound 4.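

In this assay, compound 4 gives no number, only a limit: the limit of > 500 ug/mL in this assay, at which 1 of the 4 values shown sits.

From the compounds shown here alone, replacing amino with chloro on the aromatic carbon ortho to a fluoro group and para to a chloro group gives an at least 8.4-fold higher number from compound 2 to compound 4 (0.92 log units; beyond the scatter), so the true size of the step remains unknown. For the compounds shown here, the earlier compounds all kept the amino group and differed only at another aromatic carbon, so this is the first evidence that the carbon carrying the amino group also bears on this read-out, with inhibition weakening clearly when chloro stands there.

A single exchange cannot separate the loss of amino from the arrival of chloro. Going by these compounds, it also remains open how a hydroxyl or methyl group on this carbon would read, or whether the same exchange would have a similar effect in compound 1, which has fluoro in place of the para chloro group.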